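This account rests on a few compounds, and the source may have more. Where it says the series, first, only, none or still open, it means among the compounds named here.

Compound 3 `CC(=O)Nc1ccc(-c2nc3ccccc3[nH]2)cc1` and compound 1 `CC(=O)Nc1ccc(-c2nc3cc([N+](=O)[O-])ccc3[nH]2)cc1` share one core; compound 2 `COc1ccc(-c2nc3cc(C(F)(F)F)ccc3[nH]2)cc1` has another, and the difference between the two cores is not broken down here. In an ADME assay on Vero cells (Chlorocebus sabaeus) for cytotoxicity (on this read-out lower numbers stand for higher toxicity in this test and higher numbers for lower toxicity in this test), compound 3 gives only a limit of the assay, > 100000 nM. In this assay compound 1 likewise gives only a limit, > 100000 nM. The step that the two limits leave unreadable from compound 3 to compound 1 belongs to the change (nitro in place of hydrogen on an aromatic carbon); it cannot be read because of the limit of > 100000 nM in this assay, at which 2 of the 3 values shown sit. In this assay, among the compounds with values here, compound 2 gives 15000 nM, the only number among the three. Compound 4 `COc1ccc(-c2nc3cc(C(F)(F)F)ccc3[nH]2)c([N+](=O)[O-])c1` differs from compound 2 by nitro in place of hydrogen on an aromatic carbon, the same kind of change as from compound 3 to compound 1, but here ortho to a large group and meta to a methoxy group rather than meta and para to a fused ring. The step of no change at the digits printed from compound 2 to compound 4 (within the scatter) is expected to stay small, resting on compound 2 at 15000 nM with no readable precedent for the change. Compound 4 is estimated at 15000 nM, between 5000 nM and 50000 nM.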

Compound 4, half-maximal cytotoxic concentration: 20000 nM
Estimate against measurement, compound 4: 1.3-fold (0.12 log units) below; measured number inside the range.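

In this assay, nitro in place of hydrogen on an aromatic carbon gives a 1.3-fold higher number from compound 2 to compound 4 (0.12 log units; within the scatter), so on the core of compound 2 this change leaves the read-out unmoved at this place. Within the data shown here, this is the only readable step for the change, and it holds only for a nitro ortho to a large group and meta to a methoxy group. It does not show that the result carries over from one core to the other, as the matching step on the other core cannot be read: the limit of > 100000 nM in this assay, at which 2 of the 4 values shown sit.

Open, going by these compounds, is whether an amine or a carboxylic acid at that place on the core of compound 2 would also leave the read-out unmoved. Also open, on these data alone, is whether nitro elsewhere on that core would do the same.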